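This account rests on a few compounds, and the source may have more. Where it says the series, first, only, none or still open, it means among the compounds named here.

Of the compounds shown here, three have so far been measured in a functional assay on HCT-116 cells (Homo sapiens) for antiproliferative activity, read by CCK-8 assay, with a stated time of 72 h, tested at 8 uM; on this read-out higher numbers stand for a stronger effect at the one concentration tested and lower numbers for a weaker effect. Compound 1 `CCCCn1cnc2c(Nc3cccc(Cl)c3)nc(NCOCc3ccc(/C=C/C(=O)Nc4ccccc4N)cc3)nc21` gives 10.9%. Compound 2 `CCC(C)n1cnc2c(NCc3ccc(C(=O)Nc4ccccc4N)cc3)nc(Cl)nc21` gives 75.1%, and compound 3 `Nc1ccccc1NC(=O)c1ccc(Cn2cnc3c(Nc4ccccc4)nc(Cl)nc32)cc1` gives 83.5%. On these numbers compound 2 stands second highest of the three: its nearest neighbour is compound 3, whose number lies within the usual scatter of it, while compound 1 lies far below, well beyond the scatter.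

Compound 4 `Nc1ccccc1NC(=O)c1ccc(CNc2nc(Cl)nc3c2ncn3C2CCCC2)cc1` has not yet been measured. It differs from compound 2 in one place: cyclopentyl in place of sec-butyl on an aromatic nitrogen. Among the measured compounds shown here, no measured pair differs in only this place, so there is no measured step to lean on. Since sec-butyl and cyclopentyl are both carbon-only groups placed on the same aromatic nitrogen, the step in this assay is expected to be small, most likely none beyond the scatter, in either direction. Because compound 2 gives 75.1%, compound 4 is expected to stay close to that level. Compound 4 is therefore estimated at 72%, within a range from 50% to 90%. This means an expected step of a number 3.1 percentage points lower from compound 2 to compound 4 (within the scatter).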

Compound 4, a percentage reported as inhibition, at one concentration (the size of the read-out at that concentration, not a potency): 80.6%
Compound 4: the middle estimate sits 8.6 percentage points below what was measured; low and high end bracket the measured number.
By their numbers in this assay, from the lowest: compound 1; then compounds 2, 4 and 3 (each within the scatter of the next).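

Swapping sec-butyl for cyclopentyl on the aromatic nitrogen of the five-membered ring gives, in this assay, a number 5.5 percentage points higher from compound 2 to compound 4 (within the scatter) and so gives the first direct reading of a change at this position alone. Within this one pair, a five-membered carbon ring on that nitrogen reads the same as an open, branched carbon group, so closing the substituent into a ring and adding one carbon produce no step that can be told from the scatter. Nothing measured here explains why the two groups read alike.

From the compounds shown here alone, two carbon-only groups cannot show how far this tolerance extends, so it remains open whether a longer chain such as hexyl, or a group carrying an amine or a carboxylic acid, would hold the same level at this nitrogen. A reading at one concentration also leaves open whether compound 2 and compound 4 would differ in potency.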